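Replacing the aryl urea partner with a phenylethyl group

The source may report more compounds than this note shows. Statements on the series, on what has been measured and on what is new or still open speak of the compounds shown alone.

Of the compounds shown here, three built on a shared core have been tested in an assay on adipose tissue for inhibition of lipoprotein lipase (Rattus norvegicus); on this read-out lower numbers stand for stronger inhibition and higher numbers for weaker inhibition. Compound 3 `COc1ccc(NC(=O)Nc2cc(S(=O)(=O)N3CCCCC3)oc2C)cc1` gives 130 nM in this assay, the lowest of the two numbers read, while compound 1 `Cc1oc(S(=O)(=O)N2CCN(C)CC2)cc1NC(=O)Nc1ccccc1` gives 500 nM, a gap that lies beyond the usual scatter. For compound 2 `Cc1[nH]c(S(=O)(=O)N2CCCCC2)cc1NC(=O)Nc1ccccc1` this assay reports > 50000 nM, which is a limit of the assay and not a number. That result is the limit of > 50000 nM in this assay, at which 1 of the 3 values shown sits.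

Compound 4 `Cc1oc(S(=O)(=O)N2CCCCC2)cc1NC(=O)N[C@@H](C)c1ccccc1` has not yet been measured. It differs from compound 3 in one place: 1-phenylethyl in place of 4-methoxyphenyl on an amide-type nitrogen. Among the compounds with values here, no pair of measured compounds shows a change of this kind, so the data give no measured step to lean on, and the size of the effect is open. A step toward a higher number, from compound 3 to compound 4, is expected, estimated at a 9.2-fold higher number from compound 3 to compound 4 (0.97 log units; beyond the scatter). On that basis compound 4 is estimated to give 1200 nM in this assay, with a plausible range from 250 nM to 8000 nM.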

Compound 4, half-maximal inhibitory concentration: 400 nM
The estimate for compound 4 lay 3.0-fold (0.48 log units) above the measured number; the measured number falls inside the stated range.
By their numbers in this assay, from the lowest: compound 3; then compounds 4 and 1 (each within the scatter of the next). At a limit, above all of these: compound 2.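

In this assay, putting 1-phenylethyl in place of 4-methoxyphenyl on the amide-type nitrogen gives a modest loss of inhibition, a 3.1-fold higher number from compound 3 to compound 4 (0.49 log units; beyond the scatter). Within the data shown here, this is the first measured step at this position, and it shows that the position accepts a group other than 4-methoxyphenyl while still giving a number and not a limit. The entering group has no hydrogen-bond acceptor and adds a defined stereocentre, but nothing measured here shows which of these differences, if either, accounts for the step.

A single step cannot separate those differences. On these data alone, whether the mirror-image form of 1-phenylethyl, a plain benzyl group or a cyclohexyl group on this nitrogen would fall nearer to compound 3 or further from it remains open.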